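Methyl for fluoro on the aryl ring of the shared core

The source may hold more compounds than are shown below. What is called first, only, known or untested is meant among the compounds shown, and "the series" means these compounds.

compound 1 `Oc1ccccc1/C=N/c1nnc(SCc2nnc(-c3ccc(F)cc3)o2)s1` gives 15600 nM in a functional assay on MCF7 cells (Homo sapiens) for inhibition, read by CCK-8 assay; on this read-out higher numbers stand for weaker inhibition and lower numbers for stronger inhibition
compound 2 `Cc1ccccc1-c1nnc(CSc2nnc(/N=C/c3ccccc3O)s2)o1` gives 9360 nM
compound 3 `Cc1cccc(-c2nnc(CSc3nnc(/N=C/c4ccccc4O)s3)o2)c1` gives 11600 nM

Compound 1 carries the highest of the three numbers, but both gaps from it are within the scatter: a 1.7-fold lower number from compound 1 to compound 2 (0.22 log units; within the scatter) and a 1.3-fold lower number from compound 1 to compound 3 (0.13 log units; within the scatter). Compound 4 `Cc1ccc(-c2nnc(CSc3nnc(/N=C/c4ccccc4O)s3)o2)cc1` differs from compound 1 by methyl in place of fluoro on an aromatic carbon. Going by the values given here, the steps that bear on this are the two other methyl-for-fluoro exchanges on the same ring, a 1.7-fold lower number from compound 1 to compound 2 (0.22 log units; within the scatter) and a 1.3-fold lower number from compound 1 to compound 3 (0.13 log units; within the scatter), and the move of the methyl between them, a 1.2-fold higher number from compound 2 to compound 3 (0.09 log units; within the scatter); none of the three left the scatter. No step beyond the scatter is therefore expected here, an estimated 1.4-fold lower number from compound 1 to compound 4 (0.15 log units; within the scatter). Compound 4 is expected to give about 11000 nM, in a range from 5000 nM to 25000 nM.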

Compound 4, half-maximal inhibitory concentration: 8750 nM
Compound 4: the middle estimate sits 1.3-fold (0.10 log units) above what was measured; low and high end bracket the measured number.
By their numbers in this assay, from the lowest: compounds 4, 2, 3 and 1 (each within the scatter of the next).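

On the 4-methylphenyl compound, the exchange of fluoro for methyl on the aromatic carbon para to a large group stays within the scatter in this assay (a 1.8-fold lower number from compound 1 to compound 4 (0.25 log units; within the scatter)). Placing the methyl on this carbon also gives no separation from the other two methylphenyl compounds (a 1.3-fold lower number from compound 3 to compound 4 (0.12 log units; within the scatter)) (a 1.1-fold lower number from compound 2 to compound 4 (0.03 log units; within the scatter)). All four compounds therefore read alike on this aryl ring, and nothing on hand speaks to a cause. Still open, from the compounds shown here alone, is whether an amine or a carboxylic acid at this place would leave the scatter.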